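The source may hold more compounds than are shown below. What is called first, only, known or untested is meant among the compounds shown, and "the series" means these compounds.

In a functional assay on HeLa cells (Homo sapiens) for antiproliferative activity, read by MTT assay, with a stated time of 48 h (a higher number here means a weaker inhibitor, a lower number a stronger inhibitor), compound 1 (`O=C(/C=C/c1ccc(O)cc1)Nc1cc2c(Nc3ccc(Cl)c(Cl)c3)ncnc2s1`) gives 24800 nM and compound 2 (`COc1ccc(/C=C/C(=O)Nc2cc3c(Nc4ccc(Cl)c(Cl)c4)ncnc3s2)cc1`) gives 33 nM while compound 3 (`O=C(/C=C/c1ccccc1)Nc1cc2c(Nc3ccc(F)c(Cl)c3)ncnc2s1`) gives 2140 nM and so stands second highest of the three numbers, between the other two. Compound 4 (`O=C(/C=C/c1ccccc1)Nc1cc2c(Nc3ccc(Cl)c(Cl)c3)ncnc2s1`) is still unmeasured and differs from compound 3 in one place: chloro in place of fluoro on an aromatic carbon. Among the compounds with values here, the only measured step (a 750-fold lower number from compound 1 to compound 2 (2.88 log units; beyond the scatter)) is large and beyond the scatter, but it is methyl in place of hydrogen on an oxygen on an aromatic ring and not this change, so it sets no size here, though it argues for a wide range. Within the data shown here, no measured pair exchanges fluoro for chloro, so the expectation starts from compound 3 at 2140 nM and foresees no step beyond the scatter in this assay in either direction. The expected step is small (a 1.4-fold lower number from compound 3 to compound 4 (0.15 log units; within the scatter)). Compound 4 is estimated at 1500 nM (expected range 300 nM to 7000 nM).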

Compound 4, half-maximal inhibitory concentration: 430 nM
Compound 4: middle estimate off by 3.5-fold (0.54 log units), on the high side, and the stated range covers the measured number.
By their numbers in this assay, from the lowest: compound 2; then compound 4; then compound 3; then compound 1.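

In this assay, the halogen on the aromatic carbon ortho to a chloro group and para to a large group proves to matter, since chloro in place of fluoro gives a 5.0-fold lower number from compound 3 to compound 4 (0.70 log units; beyond the scatter). Compound 4 also supplies the hydrogen reference for the earlier hydroxy and methoxy pair: hydrogen in place of methoxy gives a 13-fold higher number from compound 2 to compound 4 (1.11 log units; beyond the scatter), and hydrogen in place of hydroxy gives a 58-fold lower number from compound 1 to compound 4 (1.76 log units; beyond the scatter), so the two oxygen groups move the number in opposite directions from hydrogen. Nothing available explains either the halogen step or the difference between the two oxygen groups.

The compounds shown leave open whether bromo or methyl on that same carbon would go further than chloro. They also do not tell whether ethoxy or an amine in the methoxy place would keep the low number of compound 2, or whether the halogen step holds alongside methoxy.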